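The compounds below may be only part of what the source reports. "The series", "measured", "known", "first", "only" and "open" are said of these compounds alone.

Measured compounds:
Compound 1, `N#CCCCc1c[nH]c2ccc(C(=O)O)cc12`: "not active" (no number reported)
Compound 2, `CCCc1c[nH]c2ccc(F)cc12`: > 100 nM
Compound 3, `NCCSCCCc1c[nH]c2c(F)cccc12`: > 100 nM

In an assay on isolated protein for inhibition of Myeloperoxidase (Homo sapiens), read by ELISA, with a stated time of 5 min (on this read-out higher numbers stand for weaker inhibition and lower numbers for stronger inhibition), compound 2 gives > 100 nM, which is a limit of the assay and not a number. Compound 3 likewise gives > 100 nM in this assay, again a limit rather than a number. Compound 1 is reported in this assay as "not active" (no number reported), without a number. Among the measured compounds shown here, compound 2 therefore stands among values that are all limits or unnumbered, and no step between measured compounds can be drawn from them.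

Compound 4, `CNC(=O)CCCc1c[nH]c2ccc(F)cc12`, differs from compound 2 by methylcarbamoyl in place of hydrogen on a saturated chain carbon, three bonds along the chain from an aromatic carbon. For the measured compounds named here, with no measured step to lean on, the expectation for compound 4 rests on where compound 2 sits. Because (the limit of > 100 nM in this assay, at which 2 of the 3 values shown sit), compound 4 is expected to remain in the same weak region, with the step from compound 2 expected to be no larger than the scatter, a step that the limit leaves unreadable from compound 2 to compound 4. Compound 4 is thus estimated in this assay at 300 nM, within a range from 100 nM to 3000 nM.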

Compound 4, half-maximal inhibitory concentration: 95 nM
Estimate against measurement, compound 4: 3.2-fold (0.50 log units) above, and the stated range ends above it.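

In this assay compound 4 gives 95 nM, the only value among the compounds shown that is a number rather than a limit or an unnumbered report. Methylcarbamoyl in place of hydrogen on a saturated chain carbon, three bonds along the chain from an aromatic carbon, gives an at least 1.0-fold lower number from compound 2 to compound 4 (0.02 log units; that floor lies within the scatter). The full size of this step cannot be read, because compound 2 gives only a limit: the limit of > 100 nM in this assay, at which 2 of the 4 values shown sit.

The compounds shown leave open whether a dimethylcarbamoyl group or a hydroxyl group on the same carbon would also give a numbered value in this assay. They also leave open how the numbered value of compound 4 would respond to a longer chain carrying the same methylcarbamoyl group.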